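The source may hold more compounds than are shown below. What is called first, only, known or untested is meant among the compounds shown, and "the series" means these compounds.

Measured compounds:
compound 1 `CC1=CC(=O)OC(CSc2nc(-c3cccc(Cl)c3)c(-c3cccc(Cl)c3)[nH]2)C1` gives 440 nM
compound 2 `O=C1CCCC(CSc2nc(-c3ccccc3)c(-c3ccccc3)[nH]2)O1` gives 740 nM

Among the measured compounds shown here, in an assay on microsomes from liver for inhibition of sterol O-acyltransferase 1 (Rattus norvegicus) (a higher number here means a weaker inhibitor, a lower number a stronger inhibitor), compound 2 gives 740 nM, the highest of the two numbers known here. Its nearest neighbour is compound 1, which in this assay gives 440 nM; the gap between them lies within the scatter of repeated measurements, so the two compounds cannot be placed in order by these numbers alone. For the measured compounds named here, no pair of measured compounds differs in one place, so no step of known size is available to lean on.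

Compound 3 `CCOC(CCSc1nc(-c2ccccc2)c(-c2ccccc2)[nH]1)OCC` has not yet been measured. It differs from compound 2 as follows: a group of 8 heavy atoms (6 carbon, 2 oxygen; no ring) in place of a group of 7 heavy atoms (5 carbon, 2 oxygen; one six-membered non-aromatic ring with 1 hetero atom), on a saturated chain carbon bound to a sulfur.

Going by the values given here, nothing among the measured compounds speaks to this kind of change, so the expectation rests on compound 2 alone. The estimated step of a 2.0-fold higher number from compound 2 to compound 3 (0.31 log units; beyond the scatter) is expected to be small and, if anything, toward a higher number, without confidence that it will exceed the scatter. Compound 3 is expected to give about 1500 nM in this assay, with a range from 400 nM to 6000 nM.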

Compound 3, half-maximal inhibitory concentration: 69 nM
Estimate against measurement, compound 3: 22-fold (1.34 log units) above; measured number outside the range, below it.
By their numbers in this assay, from the lowest: compound 3; then compounds 1 and 2 (each within the scatter of the next).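

In this assay, among the compounds shown here, the exchange on a saturated chain carbon bound to a sulfur gives the first step of known size at this place: replacing the group with one six-membered non-aromatic ring by 2,2-diethoxyethyl gives an 11-fold lower number from compound 2 to compound 3 (1.03 log units; beyond the scatter), so what this place carries matters, and compound 3 shows that a group with no ring can go with the lower number. The counted hydrogen-bond donors, hydrogen-bond acceptors and net charge are the same in the group that leaves and the group that enters, so those counts do not separate the two compounds, whereas the ring and the double bond outside aromatic rings are lost in the exchange. No measurement shown here gives a reason for the size of this step.

The compounds shown leave open which part of the exchange carries the step: the loss of the ring, the loss of the double bond, or the two ethoxy groups themselves. From the compounds shown here alone, a 2,2-dimethoxyethyl group, a plain butyl chain or an amine at this place would bear on that, and whether the step holds on the core of compound 1 is also open.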